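Two Substituent Changes on a Shared Core, All at the Limit

A few compounds are considered here, and "the series" means these few. Any claim that something is new, unique, unknown or untested is made for them only; others in the source may bear on it.

Compound 1, `Cc1nnc(SCc2ccccc2)n1N1C(=O)c2ccccc2C1=O`, reaches only the limit of the assay in a functional assay on PC-3M cells (Homo sapiens) for cytotoxicity, read by MTT assay, with a stated time of 48 h; a higher number here means a weaker inhibitor, a lower number a stronger inhibitor: > 200000 nM.
Compound 2, `Cc1nnc(SCC(=O)c2ccc(Cl)cc2)n1N1C(=O)c2ccccc2C1=O`, also gives only a limit in this assay: > 200000 nM.
Compound 3, `CCCc1nnc(SCc2ccccc2)n1N1C(=O)c2ccccc2C1=O`, likewise gives only a limit in this assay: > 200000 nM.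

Compound 1 and compound 2 differ by (4-chlorophenyl)carbonyl in place of phenyl on a saturated chain carbon bound to a sulfur. The step that the two limits leave unreadable from compound 1 to compound 2 cannot be read because of the limit of > 200000 nM in this assay, at which 3 of the 3 values shown sit. The two cores differ by ethyl in place of hydrogen on a saturated chain carbon bound to an aromatic carbon, and the step that the two limits leave unreadable from compound 1 to compound 3 is equally unreadable for the same reason.

Compound 4, `CCCc1nnc(SCC(=O)c2ccc(Cl)cc2)n1N1C(=O)c2ccccc2C1=O`, has not yet been measured. It differs from compound 3 by (4-chlorophenyl)carbonyl in place of phenyl on a saturated chain carbon bound to a sulfur, the same change that turns compound 1 into compound 2, at the same place. The step from compound 3 to compound 4 is expected to be a step that the limit leaves unreadable from compound 3 to compound 4, and this expectation rests on compound 1, compound 2 and compound 3 all sitting at the limit, as the limit of > 200000 nM in this assay, at which 3 of the 3 values shown sit, shows. For compound 4 the estimate in this assay is 300000 nM, expected to fall between 100000 nM and 1000000 nM.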

Compound 4, half-maximal inhibitory concentration: > 200000 nM
Compound 4: only a limit was reported (the forecaster's own chance of this, stated with the estimate: 85%); the middle value is on the limit's open side.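

Compound 4 also gives only a limit in this assay, > 200000 nM. Its steps from compound 2 and compound 3 therefore cannot be read, because all four compounds sit at the same limit: the limit of > 200000 nM in this assay, at which 4 of the 4 values shown sit.

The compounds shown leave open how strongly any of them acts on these cells, and whether either substituent change makes any difference.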